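Swapping the aryl ketone for a furan on a trimethoxyphenyl triazole core

The source may hold more compounds than are shown below. What is called first, only, known or untested is meant among the compounds shown, and "the series" means these compounds.

Of the compounds shown here, three sharing one core have been tested in a functional assay on A549 cells (Homo sapiens) for cytotoxicity, read by MTT assay, with a stated time of 48 h; on this read-out higher numbers stand for weaker inhibition and lower numbers for stronger inhibition. Compound 1, with structure `COc1cc(C(=O)C2Sc3nnc(-c4cc(OC)c(OC)c(OC)c4)n3NC2c2ccco2)cc(OC)c1OC`, gives 48300 nM. Compound 2, with structure `COc1cc(-c2nnc3n2NC(c2ccco2)C(C(=O)c2ccc(F)cc2)S3)cc(OC)c1OC`, gives 53700 nM. Compound 3, with structure `COc1cc(-c2nnc3n2NC(c2ccco2)C(C(=O)c2ccc(O)cc2)S3)cc(OC)c1OC`, gives 93400 nM. The steps between them are all small: a 1.1-fold higher number from compound 1 to compound 2 (0.05 log units; within the scatter), a 1.9-fold higher number from compound 1 to compound 3 (0.29 log units; within the scatter) and a 1.7-fold higher number from compound 2 to compound 3 (0.24 log units; within the scatter). So compound 3 cannot be told apart from the other two on these numbers; changing the ring on the carbonyl carbon has so far left this assay essentially unmoved.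

Compound 4, with structure `COc1cc(-c2nnc3n2NC(c2ccco2)C(C(=O)c2ccco2)S3)cc(OC)c1OC`, continues the same kind of change: furan-2-yl in place of 4-hydroxyphenyl on a carbonyl carbon. Going by the values given here, the steps that bear on it are those that also altered the ring on the carbonyl carbon, from compound 1 to compound 2 and from compound 1 to compound 3, and both stayed within the scatter. A five-membered ring replacing a six-membered one is a somewhat larger structural move than those, but nothing in the data points in either direction. The expectation for compound 4 is therefore a step of a 1.3-fold lower number from compound 3 to compound 4 (0.13 log units; within the scatter), meaning no change beyond the scatter. Compound 4 is estimated at 70000 nM, with a range from 30000 nM to 160000 nM.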

Compound 4, half-maximal inhibitory concentration: 68700 nM
Beside the measured number, compound 4's estimate is 1.0-fold (0.01 log units) above it; the measured number falls inside the stated range.
By their numbers in this assay, from the lowest: compounds 1, 2, 4 and 3 (each within the scatter of the next).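

In this assay, the five-membered furan-2-yl ring on the carbonyl carbon reads the same as each six-membered ring tried there, with a 1.4-fold lower number from compound 3 to compound 4 (0.13 log units; within the scatter) and a 1.3-fold higher number from compound 2 to compound 4 (0.11 log units; within the scatter) and a 1.4-fold higher number from compound 1 to compound 4 (0.15 log units; within the scatter) as the three steps. Going by these compounds alone, this extends what the earlier compounds showed, since all of them carried a six-membered aromatic ring of carbon only at this position, whereas this ring is smaller and holds a hetero atom; taking away 4-hydroxyphenyl also removes its hydrogen-bond donor, and still no step leaves the scatter, so across these four compounds the number tolerates every aromatic ring placed on the carbonyl carbon. Nothing measured alongside these compounds says why the position behaves this way.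

On these data alone, all four compounds keep an aromatic ring on the carbonyl carbon, so it remains open whether a non-aromatic group there, such as a cyclohexyl ring, a short alkyl chain or a chain ending in an amine, would give a step beyond the scatter. As far as these compounds go, the furan-2-yl on the saturated ring carbon and the trimethoxyphenyl on the shared core stay the same throughout, so the effect of replacing either of them, for example with a pyridine ring, also remains open.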